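Swapping the Pendant Aryl Group on a Shared Core

A few compounds are considered here, and "the series" means these few. Any claim that something is new, unique, unknown or untested is made for them only; others in the source may bear on it.

Compound 2 `Cc1nc2c3ccccc3ccc2c2nc3c(ccc4ccccc43)c(-c3cc([N+](=O)[O-])ccc3N)c12` holds the lower of the two numbers obtained so far in a functional assay, read by spectrophotometry, with a stated time of 30 min; on this read-out lower numbers stand for stronger inhibition and higher numbers for weaker inhibition. In this assay compound 2 gives 93.1 ug/mL, while compound 1 `Cc1nc2c3ccccc3ccc2c2nc3c(ccc4ccccc43)c(-c3cccc4ccccc34)c12` gives 111 ug/mL. The step between them, a 1.2-fold lower number from compound 1 to compound 2 (0.08 log units; within the scatter), lies within the scatter, so the two values cannot be told apart. Compound 3 `Cc1nc2c3ccccc3ccc2c2nc3c(ccc4ccccc43)c(-c3ccccc3S)c12` has not yet been measured in this assay. It differs from compound 2 in one place: 2-sulfanylphenyl in place of 2-amino-5-nitrophenyl on an aromatic carbon. For the measured compounds named here, the only measured step that bears on this is the earlier exchange at the same place, a 1.2-fold lower number from compound 1 to compound 2 (0.08 log units; within the scatter), which did not move the number beyond the scatter. With nothing in the data pointing to a larger effect, a step of a 1.1-fold higher number from compound 2 to compound 3 (0.03 log units; within the scatter) is expected, that is, no change beyond the scatter. Compound 3 is therefore estimated to give 100 ug/mL in this assay, with a range from 45 ug/mL to 220 ug/mL.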

Compound 3, half-maximal inhibitory concentration: 89 ug/mL
For compound 3 the middle estimate is 1.1-fold (0.05 log units) above the measured one, and the stated range covers the measured number.
By their numbers in this assay, from the lowest: compounds 3, 2 and 1 (each within the scatter of the next).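

With 2-sulfanylphenyl, a third kind of aryl group has now been read at this position on the shared core in this assay, and it shows a 1.0-fold lower number from compound 2 to compound 3 (0.02 log units; within the scatter) and also a 1.2-fold lower number from compound 1 to compound 3 (0.10 log units; within the scatter) in the comparison with the naphthalen-1-yl compound. All three groups therefore give numbers within the scatter of one another, even though the entering group carries sulfur and has neither the amino nor the nitro group of 2-amino-5-nitrophenyl. No measurement shown here offers an explanation for this result.

As far as these compounds go, all three compounds carry a six-membered aromatic ring of carbon only at this place, so it remains open whether a carboxylic acid, a simple amine or a longer alkyl chain there would give a different number. No step shown goes beyond the scatter, so the size of change this position can produce is still unknown.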